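The compounds below may be only part of what the source reports. "The series", "measured", "known", "first", "only" and "open" are said of these compounds alone.

Of the compounds shown here, three built on one shared core have been measured so far, and they differ only in the group carried on one aromatic carbon of the phenyl ring. Compound 1 `O=C(/C=C/c1cc2ccccc2nc1Cl)c1ccccc1` carries a hydrogen there; in an assay on nucleic acid for binding affinity to Calf thymus DNA (Bos taurus) (a higher number here means a weaker inhibitor, a lower number a stronger inhibitor), compound 1 gives 572 nM. Compound 2 `Cc1ccc(C(=O)/C=C/c2cc3ccccc3nc2Cl)cc1` carries a methyl, and in this assay compound 2 gives 540 nM. Compound 3 `O=C(/C=C/c1cc2ccccc2nc1Cl)c1ccc(Cl)cc1` carries a chloro, and in this assay compound 3 gives 562 nM. The three numbers sit close together: a 1.1-fold lower number from compound 1 to compound 2 (0.03 log units; within the scatter), a 1.0-fold lower number from compound 1 to compound 3 (0.01 log units; within the scatter) and a 1.0-fold higher number from compound 2 to compound 3 (0.02 log units; within the scatter) are all within the scatter of repeated measurements, so none of the three can be called stronger or weaker than another. Compound 3 thus stands among values that the assay cannot tell apart.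

Compound 4 `O=C(/C=C/c1cc2ccccc2nc1Cl)c1ccc(Br)cc1` has not yet been measured. It differs from compound 3 in one place: bromo in place of chloro on an aromatic carbon. Within the data shown here, two measured steps bear on this change, both made at the same aromatic carbon: a 1.0-fold lower number from compound 1 to compound 3 (0.01 log units; within the scatter) and a 1.0-fold higher number from compound 2 to compound 3 (0.02 log units; within the scatter). Exchanging hydrogen, methyl or chloro at this carbon has left the number unchanged within the scatter, so the step to bromo is expected to be a 1.0-fold lower number from compound 3 to compound 4 (0.00 log units; within the scatter), with no shift beyond the scatter. Compound 4 is therefore estimated at 560 nM, expected to lie between 350 nM and 900 nM.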

Compound 4, inhibition constant: 468 nM
For compound 4 the middle estimate is 1.2-fold (0.08 log units) above the measured one, and the stated range covers the measured number.
By their numbers in this assay, from the lowest: compounds 4, 2, 3 and 1 (each within the scatter of the next).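

Bromo now joins hydrogen, methyl and chloro at this carbon, para to a large group, and in this assay the new steps read a 1.2-fold lower number from compound 3 to compound 4 (0.08 log units; within the scatter) and a 1.2-fold lower number from compound 2 to compound 4 (0.06 log units; within the scatter) and a 1.2-fold lower number from compound 1 to compound 4 (0.09 log units; within the scatter) with all of them inside the scatter. Exchanging one halogen for the next therefore leaves the assay unable to separate the two compounds, and the series of four groups gives no ranking and no trend, even though these steps are somewhat larger in size than those among the first three compounds. Nothing available here explains why the number holds so steady across these groups.

On these data alone, all four groups are small and sit on the same aromatic carbon, so it remains open whether an amine, a carboxylic acid or a longer chain at this carbon would shift the number beyond the scatter. As far as these compounds go, it also remains open whether the same flat picture would hold for a bromo or a methyl on another carbon of this ring, or whether changes elsewhere on the shared core matter more.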